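This account rests on a few compounds, and the source may have more. Where it says the series, first, only, none or still open, it means among the compounds named here.

Compound 3 `CCc1ccccc1N(CC(=O)NCc1ccc(Cl)cc1)S(=O)(=O)c1ccc(C)cc1` gives 11.5 nM in a functional assay on CHO-K1 cells for antagonist activity at prostaglandin E2 receptor EP1 subtype (Homo sapiens), read by FLIPR and calcium flux (on this read-out higher numbers stand for weaker inhibition and lower numbers for stronger inhibition), the lowest of the three numbers measured. Compound 2 `CCc1ccccc1N(CC(=O)NCc1cccc(OC)c1)S(=O)(=O)c1ccc(C)cc1` gives 138 nM, and compound 1 `CCc1ccccc1N(CC(=O)NCc1ccc(OC)c(OC)c1)S(=O)(=O)c1ccc(C)cc1` gives 282 nM; the steps of a 12-fold lower number from compound 2 to compound 3 (1.08 log units; beyond the scatter) and a 25-fold lower number from compound 1 to compound 3 (1.39 log units; beyond the scatter) are both large, while a 2.0-fold lower number from compound 1 to compound 2 (0.31 log units; beyond the scatter) is modest. Compound 4 `Cc1ccc(S(=O)(=O)N(CC(=O)NCc2ccc(Cl)cc2)c2ccc(C)cn2)cc1` differs from compound 3 at one place only: 5-methylpyridin-2-yl in place of 2-ethylphenyl on a sulfonamide nitrogen. Among the compounds with values here, none of the measured steps touches the sulfonamide nitrogen; all three vary the group on the saturated chain carbon bound to the amide-type nitrogen, so no measured step bears on the exchange of 2-ethylphenyl for 5-methylpyridin-2-yl. The step of a 1.6-fold higher number from compound 3 to compound 4 (0.19 log units; within the scatter) is therefore expected to lie within the scatter, with a wide range reflecting the lack of guidance. The estimate for compound 4 in this assay is 18 nM, within 4 nM to 90 nM.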

Compound 4, inhibition constant: < 1450 nM
Compound 4 gave a limit, no number (the forecaster's own chance of this, stated with the estimate: 5%); the middle value does not contradict the limit.
By their numbers in this assay, from the lowest: compound 3; then compound 2; then compound 1.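

Within the data shown here, compound 4 gave only a limit, < 1450 nM, not a number, so no step from compound 3 to compound 4 can be read. The compounds shown leave open how 5-methylpyridin-2-yl in place of 2-ethylphenyl on a sulfonamide nitrogen alters inhibition.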